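The compounds below may be only part of what the source reports. "The series", "measured", "known", "first", "only" and "open" are said of these compounds alone.

Measured compounds in an ADME assay on MT4 cells (Homo sapiens) for cytotoxicity, read by MTT assay, with a stated time of 4 days; on this read-out lower numbers stand for higher toxicity in this test and higher numbers for lower toxicity in this test:
compound 1 `Cc1cc(C#N)cc(C)c1Oc1nc(Nc2ccc(C#N)cc2)nc2ccccc12` gives 203000 nM
compound 2 `N#Cc1ccc(Nc2nc(Oc3ccc(Cl)cc3Cl)c3ccccc3n2)cc1` gives 32000 nM
compound 3 `Cc1cccc(C)c1Oc1nc(Nc2ccc(C#N)cc2)nc2ccccc12` gives 35000 nM

Compound 1 has the highest number of the three; its nearest neighbour is compound 3 at a 5.8-fold lower number from compound 1 to compound 3 (0.76 log units; beyond the scatter) and its furthest is compound 2 at a 6.3-fold lower number from compound 1 to compound 2 (0.80 log units; beyond the scatter). Compound 2 and compound 3 sit together, a 1.1-fold higher number from compound 2 to compound 3 (0.04 log units; within the scatter).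

Compound 4 `Cc1ccccc1Oc1nc(Nc2ccc(C#N)cc2)nc2ccccc12` has not yet been measured in this assay. Against compound 1 the change is 2-methylphenyl in place of 4-cyano-2,6-dimethylphenyl on an oxygen on an aromatic ring.

For the measured compounds named here, two measured steps bear on this. The step from compound 1 to compound 3, hydrogen in place of cyano on an aromatic carbon, gave a 5.8-fold lower number from compound 1 to compound 3 (0.76 log units; beyond the scatter). The step from compound 1 to compound 2, a different group on the same oxygen, gave a 6.3-fold lower number from compound 1 to compound 2 (0.80 log units; beyond the scatter). Both departures from compound 1 lowered the number by a similar modest amount, and the pair compound 2 and compound 3 shows no separation. Going by the values given here, compound 4 shares with compound 3 the absence of cyano on that ring and differs from it only in the pattern of methyl groups, a kind of change for which no measured step is available.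

The expectation is therefore a modest lower number, a 5.8-fold lower number from compound 1 to compound 4 (0.76 log units; beyond the scatter), close to compound 3. Compound 4 is estimated at 35000 nM, with a range of 12000 nM to 100000 nM.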

Compound 4, half-maximal cytotoxic concentration: 355000 nM
Compound 4: middle estimate off by 10-fold (1.01 log units), on the low side, outside the stated range (above it).
By their numbers in this assay, from the lowest: compounds 2 and 3 (each within the scatter of the next); then compounds 1 and 4 (each within the scatter of the next).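

In this assay the number on this series does not follow the cyano group alone: the removal of one methyl group from the ring on the oxygen gives a large step (a 10-fold higher number from compound 3 to compound 4 (1.01 log units; beyond the scatter)). Compound 4 also lacks the cyano group, yet it stays level with compound 1 (a 1.7-fold higher number from compound 1 to compound 4 (0.24 log units; within the scatter)), so the step seen on removing cyano while both methyl groups remain (a 5.8-fold lower number from compound 1 to compound 3 (0.76 log units; beyond the scatter)) does not carry over to the ring with one methyl group. The 2-methylphenyl group also stands well apart from 2,4-dichlorophenyl (an 11-fold higher number from compound 2 to compound 4 (1.05 log units; beyond the scatter)), whereas 2,6-dimethylphenyl does not (a 1.1-fold higher number from compound 2 to compound 3 (0.04 log units; within the scatter)), so the number depends on the full set of groups on this ring and not on any one of them.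

No measurement here offers a reason for these steps, and why a single methyl group matters so much remains unexplained. The compounds shown also leave open whether the high numbers hold when a methoxy group, an amine or a carboxylic acid stands in place of the methyl of the 2-methylphenyl group.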